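One Methoxy Group Fewer on a Shared Core

A few compounds are considered here, and "the series" means these few. Any claim that something is new, unique, unknown or untested is made for them only; others in the source may bear on it.

Two compounds share a core and differ only in how many methoxy groups sit on one aromatic ring. Compound 1 `COc1ccc(-c2cc(/C=C/C(=O)c3ccc(N)cc3)[nH]n2)cc1` carries a single methoxy group; compound 2 `COc1cc(-c2cc(/C=C/C(=O)c3ccc(N)cc3)[nH]n2)cc(OC)c1OC` carries three. In a functional assay on KM12 cells (Homo sapiens) for inhibition, read by sulforhodamine B assay, with a stated time of 48 h (on this read-out higher numbers stand for weaker inhibition of growth and lower numbers for stronger inhibition of growth), compound 1 gives 1540 nM, and in this assay compound 2 gives 1410 nM. Compound 2 has the lower of the two numbers, but its gap to compound 1 lies within the usual scatter, so the two cannot be told apart. Going by the values given here, no measured pair differs in a single place, so there is no measured step to lean on. Compound 3 `COc1ccc(-c2cc(/C=C/C(=O)c3ccc(N)cc3)[nH]n2)cc1OC` is made from compound 2 by the change (hydrogen in place of methoxy on an aromatic carbon), leaving two methoxy groups. With compound 1 at 1540 nM and compound 2 at 1410 nM sitting so close, the expected step in this assay is a 1.0-fold lower number from compound 2 to compound 3 (0.00 log units; within the scatter), small and without a clear direction. Compound 3 is therefore estimated at 1400 nM, with a range from 600 nM to 3500 nM.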

Compound 3, concentration for 50% growth inhibition: 1680 nM
Compound 3: the middle estimate sits 1.2-fold (0.08 log units) below what was measured; measured number inside the range.
By their numbers in this assay, from the lowest: compounds 2, 1 and 3 (each within the scatter of the next).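

Going by these compounds alone, until now no two measured compounds differed in one place, and compound 3 supplies two such pairs on the methoxy-bearing ring. In this assay, the step of a 1.2-fold higher number from compound 2 to compound 3 (0.08 log units; within the scatter) and the step of a 1.1-fold higher number from compound 1 to compound 3 (0.04 log units; within the scatter) both lie within the scatter, so at this place, ortho to a methoxy group and meta to a large group, a methoxy group and a hydrogen cannot be told apart, and the same holds for the swap that links compound 1 to compound 3. No outside evidence bears on this result.

Still open, going by these compounds, is whether another group at this place, such as an amine, a carboxylic acid or a longer chain like butoxy, would move the number beyond the scatter. Also open, on these data alone, is whether these methoxy swaps would read the same way in other cell lines.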